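This account rests on a few compounds, and the source may have more. Where it says the series, first, only, none or still open, it means among the compounds named here.

Measured compounds:
compound 1, `COc1ccc(N2C[C@@H](C)N[C@@H](C)C2)cc1NS(=O)(=O)c1ccc(-c2ccccn2)s1`: 1.1
compound 2, `CC(=O)c1ccc(N2C[C@@H](C)N[C@@H](C)C2)cc1NS(=O)(=O)c1ccc(-c2ccccn2)s1`: 0.9
compound 3, `COc1ccc(F)c(-c2ccc(S(=O)(=O)Nc3cc(N4C[C@@H](C)N[C@@H](C)C4)ccc3OC)cc2)c1`: 1.2

In a functional assay for agonist activity at growth hormone secretagogue receptor type 1 (Homo sapiens), read by FLIPR (on this read-out lower numbers stand for smaller maximal responses and higher numbers for larger maximal responses), compound 3 stands highest of the three numbers, though its gap to compound 1 is within the scatter; only compound 2 sits clearly below it. Compound 4, `COc1ccc(N2C[C@@H](C)N[C@@H](C)C2)cc1NS(=O)(=O)c1ccc(-n2cccn2)cc1`, has not yet been measured. Its change from compound 3 is 1H-pyrazol-1-yl in place of 2-fluoro-5-methoxyphenyl on an aromatic carbon, on an aromatic carbon of a six-membered aromatic ring of carbon only, para to a large group. For the measured compounds named here, the one measured step, a number 0.20 lower from compound 1 to compound 2 (beyond the scatter), concerns a different place, the substituent on the shared core, and so does not bear on this change directly. Compound 1 and compound 3 differ from each other away from the core, in the group carried on the sulfonamide side, and their values lie within the scatter of each other, so variation at that end has so far left the maximal response unchanged. For compound 4 no step beyond the scatter is therefore expected, a number 0.20 lower from compound 3 to compound 4 (beyond the scatter). The estimate for compound 4 is 1, within 0.8 to 1.2.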

Compound 4, intrinsic activity: the largest response reached, as a fraction of the reference agonist's: 0.8
Estimate against measurement, compound 4: 0.20 above; the range from low to high includes it.
By their numbers in this assay, from the lowest: compounds 4 and 2 (each within the scatter of the next); then compounds 1 and 3 (each within the scatter of the next).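

In this assay, this place on an aromatic carbon, para to a large group, is not neutral: 1H-pyrazol-1-yl in place of 2-fluoro-5-methoxyphenyl gives a number 0.40 lower from compound 3 to compound 4 (beyond the scatter). The maximal response therefore depends on the group here as well as on the substituent on the shared core, and this step is large. No supporting data are available to account for the step.

This single change swaps a six-membered aromatic ring of carbon only, carrying fluoro and methoxy groups, for a smaller five-membered aromatic ring with 2 hetero atoms, so the contribution of each difference cannot be separated. An unsubstituted phenyl at this place would separate ring identity from the fluoro and methoxy groups, while a morpholine would show how a non-aromatic ring behaves here.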